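Double-bond geometry in the alkynyl uracil series

The source may hold more compounds than are shown below. What is called first, only, known or untested is meant among the compounds shown, and "the series" means these compounds.

Compound 3 `O=C1c2ccccc2C(=O)N1C/C=C\Cn1cc(C#CCCc2ccccc2)c(=O)[nH]c1=O` stands at the limit of > 100000 nM in this assay, at which 1 of the 3 values shown sits; in a functional assay on MCF7 cells (Homo sapiens) for antiproliferative activity, read by MTT assay, with a stated time of 3 days (a lower number here means a stronger inhibitor, a higher number a weaker inhibitor), compound 3 returns only the limit > 100000 nM, not a number. Compound 4 `O=C1c2ccccc2C(=O)N1C/C=C/Cn1cc(C#CCCc2ccccc2)c(=O)[nH]c1=O` keeps every atom and bond of compound 3: the two compounds have the same atoms and bonds and differ only in configuration as drawn: 1 of 1 stereo elements differ; a double bond is drawn Z in compound 3 and E in compound 4. For the measured compounds named here, none of the measured steps concerns a change of configuration. Going by the values given here, the only single-place step, a 1.8-fold higher number from compound 1 to compound 2 (0.26 log units; within the scatter), compares compound 1 `CCCCCCC#Cc1cn(C/C=C/CN2C(=O)c3ccccc3C2=O)c(=O)[nH]c1=O` at 24000 nM with compound 2 `CCCCc1ccc(C#Cc2cn(C/C=C/CN3C(=O)c4ccccc4C3=O)c(=O)[nH]c2=O)cc1` at 44000 nM, both drawn with the same double-bond geometry as compound 4. Compound 4 is therefore expected near those two numbers, and the step of an at least 2.5-fold lower number from compound 3 to compound 4 (0.39 log units; beyond the scatter) is expected to start from a limit, so its size cannot be fixed. The estimate for compound 4 in this assay is 40000 nM, with a range from 15000 nM to 100000 nM.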

Compound 4, half-maximal inhibitory concentration: 13000 nM
The estimate for compound 4 lay 3.1-fold (0.49 log units) above the measured number, outside the stated range (below it).
By their numbers in this assay, from the lowest: compounds 4, 1 and 2 (each within the scatter of the next, the first and the last beyond it). At a limit, above all of these: compound 3.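

In this assay the geometry of the double bond alone separates this pair, the step being an at least 7.6-fold lower number from compound 3 to compound 4 (0.88 log units; beyond the scatter): the fact that compounds 3 and 4 differ only in the configuration as drawn. Compound 3 gives only a limit, not a number, so the true size of that step stays unfixed: the limit of > 100000 nM in this assay, at which 1 of the 4 values shown sits. On the triple-bonded carbon, phenethyl in place of 4-butylphenyl gives a 3.4-fold lower number from compound 2 to compound 4 (0.53 log units; beyond the scatter), while phenyl in place of butyl on the saturated chain gives a 1.8-fold lower number from compound 1 to compound 4 (0.27 log units; within the scatter).

From the compounds shown here alone, only compound 3 is drawn Z, so whether geometry matters equally with hexyl or 4-butylphenyl remains open. Also open, going by these compounds, is the effect of an amine or a carboxylic acid in place of the phenyl of phenethyl.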